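A few compounds are considered here, and "the series" means these few. Any claim that something is new, unique, unknown or untested is made for them only; others in the source may bear on it.

All three measured compounds share one core, and they differ only in the aromatic group carried on the nitrogen. Compound 1 `C#Cc1cccc(Nc2ncnc3cc(OC)c(OCCCCC(=O)Nc4ccc(S(N)(=O)=O)cc4)cc23)c1` gives 18800 nM in a functional assay on NCI-H1975 cells (Homo sapiens) for antiproliferative activity, read by MTT assay, with a stated time of 72 h; a higher number here means a weaker inhibitor, a lower number a stronger inhibitor. Compound 2 `COc1cc2ncnc(Nc3cccc(Br)c3)c2cc1OCCCCC(=O)Nc1ccc(S(N)(=O)=O)cc1` gives 11400 nM in this assay, and compound 3 `COc1cc2ncnc(Nc3ccc(F)c(Br)c3)c2cc1OCCCCC(=O)Nc1ccc(S(N)(=O)=O)cc1` gives 31600 nM in this assay. Compound 3 stands at the upper end of these numbers: the step of a 2.8-fold higher number from compound 2 to compound 3 (0.44 log units; beyond the scatter) lies beyond the scatter, whereas the step of a 1.7-fold higher number from compound 1 to compound 3 (0.23 log units; within the scatter) stays within it.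

The next compound, compound 4 `CCc1ccc(Nc2ncnc3cc(OC)c(OCCCCC(=O)Nc4ccc(S(N)(=O)=O)cc4)cc23)cc1`, changes the same group again: 4-ethylphenyl in place of 3-bromo-4-fluorophenyl on a nitrogen on an aromatic ring. Among the compounds with values here, no measured step shows 4-ethylphenyl at this place, so what bears on it are the steps at the same position. The step of a 1.6-fold lower number from compound 1 to compound 2 (0.22 log units; within the scatter) and the step of a 1.7-fold higher number from compound 1 to compound 3 (0.23 log units; within the scatter) were both within the scatter, and only a 2.8-fold higher number from compound 2 to compound 3 (0.44 log units; beyond the scatter) went modestly beyond it. Exchanging this aromatic group has therefore moved the number little so far, and the expectation for compound 4 is a small change, with the removal of the fluorine leaning toward a somewhat lower number, as a 2.8-fold higher number from compound 2 to compound 3 (0.44 log units; beyond the scatter) suggests in reverse. Compound 4 is accordingly estimated at 20000 nM in this assay, a step of a 1.6-fold lower number from compound 3 to compound 4 (0.20 log units; within the scatter), with a range from 7000 nM to 60000 nM.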

Compound 4, half-maximal inhibitory concentration: 10300 nM
Estimate against measurement, compound 4: 1.9-fold (0.29 log units) above, and the stated range covers the measured number.
By their numbers in this assay, from the lowest: compounds 4, 2, 1 and 3 (each within the scatter of the next, the first and the last beyond it).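

Exchanging 3-bromo-4-fluorophenyl for 4-ethylphenyl, which has the same count of heavy atoms but only carbon among them, gives a 3.1-fold lower number from compound 3 to compound 4 (0.49 log units; beyond the scatter) in this assay, so the number at this position does not depend on a halogen on the ring. The other two steps, a 1.1-fold lower number from compound 2 to compound 4 (0.04 log units; within the scatter) and a 1.8-fold lower number from compound 1 to compound 4 (0.26 log units; within the scatter), show that 4-ethylphenyl cannot be told apart from 3-bromophenyl or 3-ethynylphenyl in this assay, even though the ethyl group is carried on a different ring position from the bromo and ethynyl groups. Compound 3 is now set apart from both compound 2 and compound 4, yet it remains within the scatter of compound 1, so the pattern is not clean, and nothing at hand explains the gap between compound 3 and compound 4.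

The compounds shown leave open what an amine or a carboxylic acid on this aromatic ring would do, and whether an ethyl group elsewhere on the ring would give a similar number. From the compounds shown here alone, all four also share the same core and chain, so the effect of a longer chain stays open as well.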